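Selenium Esters on Colon Cancer Cells: From Ketone to Ester

The compounds below may be only part of what the source reports. "The series", "measured", "known", "first", "only" and "open" are said of these compounds alone.

Of the compounds shown here, two have been measured in a functional assay on COLO 320 cells (Homo sapiens) for cytotoxicity, read by MTT assay, with a stated time of 24 h; on this read-out higher numbers stand for weaker inhibition and lower numbers for stronger inhibition. Compound 1 `COc1cc(OC)cc(C(=O)[Se]CC(=O)C(C)(C)C)c1` gives 350 nM in this assay. Compound 2 `CC(C)(C)C(=O)C[Se]C(=O)c1ccc(Cl)cc1` gives 960 nM in this assay, the higher of the two numbers, so among the measured pair it is the weaker inhibitor, and the gap to compound 1 lies beyond the usual scatter.

Compound 3 `COC(=O)C[Se]C(=O)c1ccc(Cl)cc1` has not yet been measured. It differs from compound 2 in one place: methoxy in place of tert-butyl on a carbonyl carbon. Among the compounds with values here, no measured pair in this set shows what such a change does, so the expectation rests on compound 2 alone. The step from compound 2 to compound 3 is expected to be modest, a 1.4-fold higher number from compound 2 to compound 3 (0.13 log units; within the scatter), and may well stay within the scatter, with a slight lean toward a higher number. Compound 3 is therefore estimated at 1300 nM in this assay, within a range from 400 nM to 4000 nM.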

Compound 3, half-maximal inhibitory concentration: > 100000 nM
Compound 3: only a limit was reported; the forecaster's own chance of this, stated with the estimate: 5%; middle value at least 76-fold (1.88 log units) away from the limit.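

In this assay, the group on this carbonyl carbon turns out to matter a great deal: methoxy in place of tert-butyl gives an at least 100-fold higher number from compound 2 to compound 3 (2.01 log units; beyond the scatter). The earlier compounds shown here differed only in the part on the other side of the selenium, so they gave no hint that this single swap, which turns a ketone into an ester, could remove nearly all of the measurable effect on these cells. The result for compound 3 is a limit and not a number, so the full size of the step stays unknown: the limit of > 100000 nM in this assay, at which 1 of the 3 values shown sits.

This one pair cannot separate the loss of tert-butyl from the arrival of methoxy. An amine or a plain methyl on the same carbonyl carbon could help tell these apart, and the same swap on the core of compound 1 remains an open question.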